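Swapping Phenyl for Amino on the Amide Nitrogen

The compounds below may be only part of what the source reports. "The series", "measured", "known", "first", "only" and "open" are said of these compounds alone.

Three compounds sharing one core were tested in a functional assay on HCT-116 cells (Homo sapiens) for cytotoxicity, read by MTT assay, with a stated time of 72 h; on this read-out lower numbers stand for stronger inhibition and higher numbers for weaker inhibition. Compound 1 `CCOc1ccc2cc(C(=O)NCCO)c(=O)oc2c1` reaches only the assay limit of > 100000 nM, so no number is known for it. Compound 2 `O=C(NCCNC(=O)c1cc2ccc(OCc3cccc(Br)c3)cc2oc1=O)c1cc2ccc(OCc3cccc(Br)c3)cc2oc1=O`, which joins two copies of the core through a linker, gives 11600 nM. Compound 3 `O=C(Nc1ccccc1)c1cc2ccc(OCc3ccccc3)cc2oc1=O` likewise stops at the limit of > 100000 nM. Compound 3 thus stands at the limit of > 100000 nM in this assay, at which 2 of the 3 values shown sit, with nothing measured beyond it. Compound 4 `NNC(=O)c1cc2ccc(OCc3ccccc3)cc2oc1=O` differs from compound 3 in one place: amino in place of phenyl on an amide-type nitrogen. No measured pair shows this change, so the expectation rests on the shown values alone. This step is expected to be an at least 1.2-fold lower number from compound 3 to compound 4 (0.09 log units; that floor lies within the scatter), possibly no more than the usual scatter. Compound 4 is estimated at 80000 nM, between 20000 nM and 300000 nM.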

Compound 4, half-maximal inhibitory concentration: > 100000 nM
Compound 4: no number, only a limit; the forecaster's own chance of this, stated with the estimate: 60%; middle value at least 1.2-fold (0.09 log units) away from the limit.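

Compound 3 and compound 4 each give only a limit, so the step between them cannot be read: the limit of > 100000 nM in this assay, at which 3 of the 4 values shown sit.

The compounds shown leave open whether phenyl or amino on the amide-type nitrogen gives the lower number in this assay.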